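Undefined Ring Stereocentre in a Thromboxane Antagonist Series

A few compounds are considered here, and "the series" means these few. Any claim that something is new, unique, unknown or untested is made for them only; others in the source may bear on it.

Compound 1 `O=C(O)CC/C=C\CO[C@H]1[C@@H](OCc2ccc(-c3ccccc3CO)cc2)CC[C@@H]1N1CCCCCC1` is tested in a functional assay on blood for antagonist activity at thromboxane A2 receptor (Homo sapiens) (on this read-out higher numbers stand for weaker binding and lower numbers for tighter binding), and compound 1 gives 1.59 nM, the lowest of the two numbers recorded. Compound 2 `CS(=O)(=O)Nc1ccccc1-c1ccc(CO[C@H]2CC[C@H](N3CCCCCC3)[C@H]2OC/C=C\CCC(=O)O)cc1` gives 6.31 nM in this assay; the step of a 4.0-fold higher number from compound 1 to compound 2 (0.60 log units; beyond the scatter) follows a methanesulfonamido in place of hydroxymethyl on an aromatic carbon.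

Compound 3 `O=C(O)CC/C=C\CO[C@H]1C(OCc2ccc(-c3ccccc3CO)cc2)CC[C@@H]1N1CCCCCC1` differs from compound 1 only as follows: the two compounds have the same atoms and bonds; at least one stereo element is drawn with a configuration in one of them and without one in the other: 1 of 4 stereo elements differ; a stereocentre at a saturated ring carbon is drawn S in compound 1 and without a configuration in compound 3. Going by the values given here, no recorded step concerns a stereocentre; the single measured step involves a different group, so it offers no guide here. Since atoms and bonds are unchanged, the step of a 1.6-fold higher number from compound 1 to compound 3 (0.20 log units; within the scatter) is expected to be small, toward slightly weaker binding at most. Compound 3 is therefore expected to give 2.5 nM in this assay, within 1 nM to 8 nM.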

Compound 3, dissociation constant: 3.16 nM
Estimate against measurement, compound 3: 1.3-fold (0.10 log units) below; the range from low to high includes it.
By their numbers in this assay, from the lowest: compounds 1, 3 and 2 (each within the scatter of the next, the first and the last beyond it).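

Going by these compounds alone, the step of a 2.0-fold higher number from compound 1 to compound 3 (0.30 log units; within the scatter) is the first reading at this saturated ring carbon, since the earlier step concerned only a group on an aromatic carbon. Leaving the configuration undrawn here therefore gives no separation from compound 1 that can be told from ordinary scatter. The only structural difference behind this reading is: the fact that one of compounds 1 and 3 is drawn with a defined configuration and the other without, at the place where they differ

From the compounds shown here alone, the drawing of compound 3 does not tell which configuration, or mixture of configurations, it contains, so the effect of the opposite, R, configuration at this carbon remains open. Also open, going by these compounds, is how a primary amide in place of hydroxymethyl on an aromatic carbon would compare.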